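The source may hold more compounds than are shown below. What is called first, only, known or untested is meant among the compounds shown, and "the series" means these compounds.

Measured in an ADME assay on BJ cells (Homo sapiens) for cytotoxicity, read by MTT assay, with a stated time of 72 h; on this read-out lower numbers stand for higher toxicity in this test and higher numbers for lower toxicity in this test:
- compound 1 `OC[C@H]1O[C@@H](n2cc(F)c3c(-c4ccco4)ncnc32)[C@H](O)[C@@H]1O`: 310 nM
- compound 2 `OC[C@H]1O[C@@H](n2cc(F)c3c(-c4c[nH]cn4)ncnc32)[C@H](O)[C@@H]1O`: > 50000 nM, a limit
- compound 3 `OC[C@H]1O[C@@H](n2cc(Cl)c3c(-c4ccccc4)ncnc32)[C@H](O)[C@@H]1O`: 44500 nM

Compound 3 has the highest of the two actual numbers, 44500 nM. Compound 4 `OC[C@H]1O[C@@H](n2cc(Cl)c3c(-c4cccs4)ncnc32)[C@H](O)[C@@H]1O` carries thiophen-2-yl in place of phenyl on an aromatic carbon. For the measured compounds named here, the only measured step at this place, an at least 160-fold higher number from compound 1 to compound 2 (2.20 log units; beyond the scatter), was large, though it does not start from phenyl. Compound 1, with furan-2-yl, the closest measured group to thiophen-2-yl, gives 310 nM, but its core also differs from that of compound 3. A large move to a lower number is therefore expected in this assay. The expected change is a 30-fold lower number from compound 3 to compound 4 (1.47 log units; beyond the scatter). Compound 4 is estimated at 1500 nM, with an expected range of 150 nM to 20000 nM.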

Compound 4, half-maximal cytotoxic concentration: 4970 nM
Beside the measured number, compound 4's estimate is 3.3-fold (0.52 log units) below it; measured number inside the range.
By their numbers in this assay, from the lowest: compound 1; then compound 4; then compound 3. At a limit, above all of these: compound 2.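

In this assay, thiophen-2-yl in place of phenyl on the shared core gives a 9.0-fold lower number from compound 3 to compound 4 (0.95 log units; beyond the scatter), the only step shown that starts from phenyl. It shows that the number at this aromatic carbon also moves beyond the scatter when one aromatic ring replaces another that lacks a hydrogen-bond donor on both sides. Nothing measured here accounts for the size of this step. The compounds shown leave open how an amine or a carboxylic acid at this place would read. They also leave open whether fluorine in place of chlorine on the core changes the number by itself.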